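A few compounds are considered here, and "the series" means these few. Any claim that something is new, unique, unknown or untested is made for them only; others in the source may bear on it.

Compound 3 `COc1ccccc1-c1cnc(OC)n1C` stands in a functional assay on MCF7 cells (Homo sapiens) for inhibition, read by colorimetric assay and MTT assay, with a stated time of 72 h (on this read-out lower numbers stand for stronger inhibition and higher numbers for weaker inhibition), at > 100000 nM as a limit of the assay and not a number. Compound 4 `C=CCCCCOc1ccccc1-c1cnc(OC)n1C` differs from it by pent-4-en-1-yl in place of hydrogen on a saturated chain carbon bound to an oxygen on an aromatic ring and so carries (hex-5-en-1-yl)oxy where one methoxy stood. Compound 1 `C=CCCCCOc1ccccc1-c1cnc(OCCC=C)n1C` at 8000 nM and compound 2 `C=CCCCCOc1ccccc1-c1cnc(OCCCC=C)n1C` at 7000 nM carry that same group, but also a longer alkenyl ether in place of the remaining methoxy. Among the compounds with values here, the only measured step, a 1.1-fold lower number from compound 1 to compound 2 (0.06 log units; within the scatter), concerns that other ether and stays within the scatter, so no measured step isolates this change. The values of compound 1 and compound 2 still point toward lower numbers. The expected step is an at least 3.3-fold lower number from compound 3 to compound 4 (0.52 log units; beyond the scatter) in this assay as an estimate. Compound 4 is estimated at 30000 nM with an expected range of 10000 nM to 100000 nM on this read-out.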

Compound 4, half-maximal inhibitory concentration: 98000 nM
For compound 4 the middle estimate is 3.3-fold (0.51 log units) below the measured one; the measured number falls inside the stated range.
By their numbers in this assay, from the lowest: compounds 2 and 1 (each within the scatter of the next); then compound 4. At a limit, above all of these: compound 3.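

Compound 3 stands in this assay at > 100000 nM, a limit of the assay and not a number. The hex-5-en-1-yl change alone reads only as an at least 1.0-fold lower number from compound 3 to compound 4 (0.00 log units; that floor lies within the scatter), so its true size stays unresolved: the limit of > 100000 nM in this assay, at which 1 of the 4 values shown sits. The other ether now shows a clear effect, since methoxy in place of the longer alkenyl ether gives a 14-fold higher number from compound 2 to compound 4 (1.15 log units; beyond the scatter) and a 12-fold higher number from compound 1 to compound 4 (1.09 log units; beyond the scatter), both large.

As far as these compounds go, whether the double bond matters remains open, and a saturated hexyl chain in place of hex-5-en-1-yl would test it. From the compounds shown here alone, an amine at the chain end also remains untested.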